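Cytotoxicity on Vero Cells: a Propyl-to-Bromo Swap

A few compounds are considered here, and "the series" means these few. Any claim that something is new, unique, unknown or untested is made for them only; others in the source may bear on it.

Compound 2 `CCCc1ccc(C(=O)Nc2cc3nc(C4CCCCC4)[nH]c3cc2N(C)C)cc1` and compound 1 `CN(C)c1cc2[nH]c(C3CCCCC3)nc2cc1NC(=O)c1ccc(Br)cc1` share a core and differ only by bromo in place of propyl on an aromatic carbon. In an ADME assay on Vero cells (Chlorocebus sabaeus) for cytotoxicity, read by resazurin assay, with a stated time of 3 days (on this read-out higher numbers stand for weaker inhibition and lower numbers for stronger inhibition), compound 2 reaches only the assay limit, > 100 ug/mL. Compound 1 likewise reaches only the limit in this assay, > 100 ug/mL. The step that the two limits leave unreadable from compound 2 to compound 1 therefore has no readable size because both compounds sit at the limit of > 100 ug/mL in this assay, at which 2 of the 3 values shown sit. Compound 3 `CCCc1ccc(C(=O)Nc2cc3nc(C4CCCCC4)[nH]c3cc2N(CC)CC)cc1` differs from compound 2 by diethylamino in place of dimethylamino on an aromatic carbon; in this assay compound 3 has no reported result, "not determined" (no result reported). Compound 4 `CCN(CC)c1cc2[nH]c(C3CCCCC3)nc2cc1NC(=O)c1ccc(Br)cc1` differs from compound 3 by the same change, (bromo in place of propyl on an aromatic carbon). Since compound 1 and compound 2 both stand at the limit of > 100 ug/mL in this assay, at which 2 of the 3 values shown sit, the step from compound 3 to compound 4 is expected to be small, and a limit rather than a number is the likely outcome. Compound 4 is expected to give 100 ug/mL in this assay.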

Compound 4, half-maximal inhibitory concentration: > 100 ug/mL
Compound 4: a limit, no number; the forecaster's own chance of this, stated with the estimate: 85%; the middle value sits exactly at the limit.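

Compound 4, like compound 1, gives a limit rather than a number, so no new step between them can be read: the limit of > 100 ug/mL in this assay, at which 3 of the 4 values shown sit.

The compounds shown leave open whether compound 1, compound 2 and compound 4 truly differ in this assay, and where compound 3 stands.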